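The source may report more compounds than this note shows. Statements on the series, on what has been measured and on what is new or still open speak of the compounds shown alone.

Measured compounds:
Compound 1, `COc1ccc(-c2nc(C)c(C(=O)CSc3nc(-c4ccc(OC)cc4)c(C#N)c(=O)[nH]3)s2)cc1`, gives 32.6% in a functional assay on U-87MG ATCC cells for antiproliferative activity against U-87 MG (Homo sapiens), read by MTT assay, with a stated time of 48 h, tested at 50 uM; on this read-out higher numbers stand for a weaker effect at the one concentration tested and lower numbers for a stronger effect.
Compound 2, `COc1ccc(-c2nc(C)c(C(=O)CSc3nc(-c4cccc(OC)c4)c(C#N)c(=O)[nH]3)s2)cc1`, gives 43.2% in the same assay.

Within the data shown here, compound 2 stands highest of the two numbers; the only step known, a number 10.6 percentage points higher from compound 1 to compound 2 (beyond the scatter), moved the methoxy group around its ring. Compound 3, `COc1cccc(-c2nc(SCC(=O)c3sc(-c4ccc(Cl)cc4)nc3C)[nH]c(=O)c2C#N)c1`, differs from compound 2 by chloro in place of methoxy on an aromatic carbon, a change at the other ring, which reads as 4-methoxyphenyl to 4-chlorophenyl. Among the measured compounds shown here, no measured step shows this change, so compound 3 is expected to stay within the scatter, with an estimated step of a number 2.2 percentage points lower from compound 2 to compound 3 (within the scatter). Compound 3 is therefore estimated at 41%, within 26% to 58%.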

Compound 3, a percentage reported as activity, at one concentration (the size of the read-out at that concentration, not a potency): 47.6%
Beside the measured number, compound 3's estimate is 6.6 percentage points below it, within the range that was stated.
By their numbers in this assay, from the lowest: compound 1; then compounds 2 and 3 (each within the scatter of the next).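

The change from 4-methoxyphenyl to 4-chlorophenyl gives a number 4.4 percentage points higher from compound 2 to compound 3 (within the scatter) in this assay, so on this read-out chloro and methoxy cannot be told apart at this place. The earlier step, a number 10.6 percentage points higher from compound 1 to compound 2 (beyond the scatter), moved a methoxy group on the other aryl group and lay beyond the scatter, whereas this first change at the 4-methoxyphenyl position does not. No measurement offered here explains this result. On these data alone, it remains open whether an amine, a carboxylic acid or a longer alkoxy chain at this place would shift the number beyond the scatter. As far as these compounds go, it is also open whether chloro would behave alike in the setting of compound 1.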